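The source may report more compounds than this note shows. Statements on the series, on what has been measured and on what is new or still open speak of the compounds shown alone.

Measured compounds:
- compound 1 (`C[C@@H](NS(=O)(=O)c1ccc(Cl)cc1)[C@H]1CC[C@@H](c2ccnc3ccc(F)cc32)CC1`) gives < 1% (a limit of the assay, not a number)
- compound 2 (`C[C@@H](CNC(=O)c1ccc(Cl)cc1)[C@H]1CC[C@@H](c2ccnc3ccc(F)cc32)CC1`) gives 32%

In an ADME assay on microsomes from liver (Mus musculus) for metabolic stability, with a stated time of 10 min, tested at 0.5 uM (a lower number here means that less of the compound is left, a higher number that more of the compound is left), compound 1 has no exact value and stands at a limit (the limit of < 1% in this assay, at which 1 of the 2 values shown sits). The next compound in view is compound 3 (`C[C@@H](NC(=O)C1CCCCC1)[C@H]1CC[C@@H](c2ccnc3ccc(F)cc32)CC1`), which is not yet measured. The change from compound 1 is cyclohexylcarbonyl in place of (4-chlorophenyl)sulfonyl on an amine nitrogen.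

Among the compounds with values here, no measured step bears on this change. Within the data shown here, the only numerical guide is therefore compound 2 (32%), and the expectation stays wide. A modest rise off the limit is expected, though a result at the limit remains possible. The expected step is small and upward (a number at least 9 percentage points higher from compound 1 to compound 3 (that floor lies within the scatter)). The estimate for compound 3 is 10% (expected range 1% to 35%).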

Compound 3, percent of the compound remaining: 5%
The estimate for compound 3 lay 5 percentage points above the measured number, within the range that was stated.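

In this assay, compound 1 stands at a limit of the assay and not at a number: the limit of < 1% in this assay, at which 1 of the 3 values shown sits. With cyclohexylcarbonyl in place of (4-chlorophenyl)sulfonyl on the amine nitrogen, this position now has an exact reading, and the step is a number at least 4 percentage points higher from compound 1 to compound 3 (that floor lies within the scatter). The floor of that step lies within the scatter, so a real gain in the compound remaining is not established by this pair.

The change replaces the sulfonyl link and the aromatic ring together, and the two compounds cannot separate these parts. From the compounds shown here alone, a 4-chlorobenzoyl group on the same nitrogen would keep the aromatic ring with a carbonyl link, while an open-chain acyl group or a cyclohexylcarbonyl bearing a carboxylic acid would test the ring itself; their readings remain open.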